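This account rests on a few compounds, and the source may have more. Where it says the series, first, only, none or still open, it means among the compounds named here.

Compound 1, `Cc1ccc(OCC(=O)N(Cc2cccs2)CC(C)C)cc1`, in an assay on HEK293 cells for agonist activity at transient receptor potential cation channel subfamily M member 8 (Homo sapiens), read by fluorescence and calcium flux, with a stated time of 15 min; on this read-out lower numbers stand for an effect already at smaller amounts and higher numbers for an effect only at larger amounts of compound: 900 nM
Compound 2, `CCC(C)N(Cc1cccs1)C(=O)COc1ccc(C)cc1`, in this assay: 2000 nM
Compound 3, `Cc1ccc(OCC(=O)N(Cc2cccs2)c2cnn(C)c2)cc1`, in this assay: 63000 nM

Compound 3 stands highest of the three numbers in this assay: the step of a 32-fold higher number from compound 2 to compound 3 (1.50 log units; beyond the scatter) separates it from its nearest neighbour, and the step of a 70-fold higher number from compound 1 to compound 3 (1.85 log units; beyond the scatter) from the furthest. Compound 4, `Cc1ccc(OCC(=O)N(Cc2cccs2)c2cn[nH]c2)cc1`, is not yet measured. It differs from compound 3 in one place: hydrogen in place of methyl on an aromatic nitrogen. Among the measured compounds shown here, none of the measured steps touches this part of the molecule. The step of a 2.2-fold higher number from compound 1 to compound 2 (0.35 log units; beyond the scatter) exchanges one alkyl group on the amide-type nitrogen for another, and the steps of a 70-fold higher number from compound 1 to compound 3 (1.85 log units; beyond the scatter) and a 32-fold higher number from compound 2 to compound 3 (1.50 log units; beyond the scatter) bring in the whole 1-methyl-1H-pyrazol-4-yl group; all three concern that group as a whole, not the methyl on its aromatic nitrogen. The removal of that methyl is a smaller change than any of them, so no step beyond the scatter is expected in this assay from compound 3 to compound 4, and the direction is left open. For compound 4 the estimate is 60000 nM, within a range from 20000 nM to 180000 nM, which means an expected step of a 1.1-fold lower number from compound 3 to compound 4 (0.02 log units; within the scatter).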

Compound 4, half-maximal effective concentration: 1.4 nM
Compound 4: the middle estimate sits 43000-fold (4.63 log units) above what was measured; measured number below the stated range.
By their numbers in this assay, from the lowest: compound 4; then compound 1; then compound 2; then compound 3.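

In this assay, among the compounds shown here, the aromatic nitrogen of the five-membered ring proves far more sensitive than the earlier compounds could reveal: the exchange of methyl for hydrogen there, the removal of a single carbon, gives a 45000-fold lower number from compound 3 to compound 4 (4.65 log units; beyond the scatter) and exceeds every earlier step. The result also changes how the earlier comparison reads, since the poor standing of the 1-methyl-1H-pyrazol-4-yl group against the two alkyl groups does not extend to the 1H-pyrazol-4-yl group, which gives a 1400-fold lower number from compound 2 to compound 4 (3.15 log units; beyond the scatter) and a 640-fold lower number from compound 1 to compound 4 (2.81 log units; beyond the scatter). No measurement at hand accounts for so large a change from so small an alteration.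

The compounds shown leave open whether any group other than hydrogen can be tolerated on this aromatic nitrogen, for instance an ethyl or a hydroxyethyl chain. They also leave open whether the same low number would hold if the 1H-pyrazol-4-yl group gave way to an imidazole or a triazole, or if the rest of the molecule were changed while this group stayed in place.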